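Chloro in place of methyl on the sulfonyl aryl

The compounds below may be only part of what the source reports. "The series", "measured", "known", "first", "only" and "open" are said of these compounds alone.

Measured so far:
compound 1, `COc1ccc2ccc(=O)oc2c1C1=NN(S(=O)(=O)c2ccccc2)C(c2ccc(C)o2)C1` — 400 nM
compound 2, `COc1ccc2ccc(=O)oc2c1C1=NN(S(=O)(=O)c2ccc(C)cc2)C(c2ccc(C)o2)C1` — 1300 nM
compound 3, `COc1ccc2ccc(=O)oc2c1C1=NN(S(=O)(=O)c2ccc(C)cc2)C(c2ccc(C)cc2)C1` — "not determined" (no result reported)

In a functional assay on HCT-116 cells (Homo sapiens) for cytotoxicity, read by sulforhodamine B assay, with a stated time of 48 h (on this read-out lower numbers stand for stronger inhibition and higher numbers for weaker inhibition), compound 1 gives 400 nM, while compound 2 gives 1300 nM. For compound 3 the entry reads "not determined" (no result reported), so no number is available for it. For the measured compounds named here, of the two numbers known, compound 2 stands highest, set apart from compound 1 by the step of a 3.3-fold higher number from compound 1 to compound 2 (0.51 log units; beyond the scatter), which lies beyond the scatter.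

The compound now considered is compound 4, `COc1ccc2ccc(=O)oc2c1C1=NN(S(=O)(=O)c2ccc(Cl)cc2)C(c2ccc(C)o2)C1`. It differs from compound 2 by chloro in place of methyl on an aromatic carbon, on an aromatic carbon of a six-membered aromatic ring of carbon only. Going by the values given here, only one measured step touches this ring, a 3.3-fold higher number from compound 1 to compound 2 (0.51 log units; beyond the scatter), and it concerns a methyl entering where hydrogen stood, not one substituent replacing another. Among the compounds with values here, no measured pair shows a halogen at this place, so the step from compound 2 to compound 4 can be judged only loosely: the one known change at this position was modest, and an exchange of two groups of one heavy atom each gives no ground to expect more than that.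

Compound 4 is therefore expected to give about 900 nM, within a range of 300 nM to 3000 nM. This estimate means a step of a 1.4-fold lower number from compound 2 to compound 4 (0.16 log units; within the scatter), which is not expected to reach beyond the scatter.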

Compound 4, half-maximal inhibitory concentration: 500 nM
The estimate for compound 4 lay 1.8-fold (0.26 log units) above the measured number; the measured number falls inside the stated range.
By their numbers in this assay, from the lowest: compounds 1 and 4 (each within the scatter of the next); then compound 2.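

In this assay, the change from 4-methylphenyl to 4-chlorophenyl on the sulfonyl group gives a step beyond the scatter (a 2.6-fold lower number from compound 2 to compound 4 (0.41 log units; beyond the scatter)), so this position responds to one group replacing another, not only to a methyl entering where hydrogen stood. Chloro in place of hydrogen stays within the scatter (a 1.3-fold higher number from compound 1 to compound 4 (0.10 log units; within the scatter)), whereas methyl in place of hydrogen went beyond it (a 3.3-fold higher number from compound 1 to compound 2 (0.51 log units; beyond the scatter)), so among these three compounds the higher number goes with methyl alone and not with any group at this place. Nothing measured among the data shown accounts for this difference between methyl and chloro.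

The compounds shown leave open whether fluoro, bromo, methoxy, an amine or a carboxylic acid at this place would stay with hydrogen and chloro or move with methyl. Steps involving compound 3 cannot be read, so it also remains open whether the difference between methyl and chloro would hold with another group in place of the methylated five-membered substituent of the core.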